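Swapping the Ether Ring for a Sulfur-Linked Chain

The source may hold more compounds than are shown below. What is called first, only, known or untested is meant among the compounds shown, and "the series" means these compounds.

Compound 1 `CC(C)COc1nc(C(C)(C)C)ccc1CNC(=O)C(C)c1ccc(NS(C)(=O)=O)c(F)c1`: 0.6 nM
Compound 2 `CC(C(=O)NCc1ccc(C(C)(C)C)nc1OC1CCCCC1)c1ccc(NS(C)(=O)=O)c(F)c1`: 2.5 nM

In an assay on cells for antagonist activity at transient receptor potential cation channel subfamily V member 1 (Homo sapiens), read by FLIPR and calcium flux, with a stated time of 6 min (a higher number here means a weaker inhibitor, a lower number a stronger inhibitor), compound 2 stands highest of the two numbers measured, with compound 1 giving the lower one. Among the compounds with values here, the step of a 4.2-fold higher number from compound 1 to compound 2 (0.62 log units; beyond the scatter) is the only measured step that bears on the change to compound 3 `CCCCCSc1nc(C(C)(C)C)ccc1CNC(=O)C(C)c1ccc(NS(C)(=O)=O)c(F)c1`, which is pentylsulfanyl in place of cyclohexyloxy on an aromatic carbon. An open chain returns, as in compound 1, but the oxygen gives way to sulfur, for which no measurement exists. A modest fall back toward compound 1 is expected, a 1.7-fold lower number from compound 2 to compound 3 (0.22 log units; within the scatter). For compound 3 the estimate is 1.5 nM, expected between 0.4 nM and 6 nM.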

Compound 3, inhibition constant: 3.1 nM
The estimate for compound 3 lay 2.1-fold (0.32 log units) below the measured number, within the range that was stated.
By their numbers in this assay, from the lowest: compound 1; then compounds 2 and 3 (each within the scatter of the next).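

In this assay, pentylsulfanyl in place of cyclohexyloxy on this aromatic carbon gives a 1.2-fold higher number from compound 2 to compound 3 (0.09 log units; within the scatter), so these two groups cannot be told apart here. Set against isobutoxy, the same pentylsulfanyl group gives a 5.2-fold higher number from compound 1 to compound 3 (0.71 log units; beyond the scatter), so an open chain alone does not bring back the value of compound 1. No evidence is available to explain either step. The compounds shown leave open whether the sulfur or the shape of the chain accounts for that gap. An isobutylsulfanyl or pentyloxy chain on this carbon would separate the two.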